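A few compounds are considered here, and "the series" means these few. Any claim that something is new, unique, unknown or untested is made for them only; others in the source may bear on it.

Measured compounds:
compound 1 `ClCc1ccc(Cn2cnc3c(Cl)ncnc32)cc1` — 3540 nM
compound 2 `ClCc1cccc(Cn2cnc3c(Cl)nc(Cl)nc32)c1` — 3230 nM
compound 3 `ClCc1ccccc1Cn1cnc2ncnc(Cl)c21` — 4160 nM

All three numbers come from a functional assay on OVCAR-3 cells (Homo sapiens) for cytotoxicity, read by sulforhodamine B assay, with a stated time of 48 h; on this read-out higher numbers stand for weaker inhibition of growth and lower numbers for stronger inhibition of growth. Among them compound 1 stands second highest of three. Its nearest neighbour is compound 2, whose number sits slightly lower, and its furthest is compound 3, whose number sits slightly higher; both gaps are within the scatter, so the three compounds cannot be told apart on these data.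

Compound 4 `ClCc1ccc(Cn2cnc3c(Cl)nc(Cl)nc32)cc1` has not yet been measured in this assay. Set against compound 1, the counted difference is chloro in place of hydrogen on an aromatic carbon of the shared core. The pair compound 1 and compound 2 is not a single-change pair, since the benzylic chloromethyl group also sits differently on the benzene ring; all that can be said is that compound 2, which carries two chloro groups on its core, gives a number within the scatter of compound 1.

Among the compounds with values here, with no measured step on this change, the expectation is that adding the second chloro group moves the number by no more than the scatter, in no particular direction; the estimated step of a 1.0-fold lower number from compound 1 to compound 4 (0.02 log units; within the scatter) is accordingly small. Compound 4 is thus expected to give about 3400 nM, within a range from 1500 nM to 7500 nM.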

Compound 4, concentration for total growth inhibition: 4370 nM
Compound 4: the middle estimate sits 1.3-fold (0.11 log units) below what was measured; low and high end bracket the measured number.
By their numbers in this assay, from the lowest: compounds 2, 1, 3 and 4 (each within the scatter of the next).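

Within the data shown here, compound 4 gives the first true single-change comparison in this set: in this assay, placing chloro in place of hydrogen on an aromatic carbon, between two ring nitrogen atoms of the shared core, gives a 1.2-fold higher number from compound 1 to compound 4 (0.09 log units; within the scatter). The earlier compounds shown here could not show this, since compound 1 and compound 2 also differ in where the chloromethyl group sits on the benzene ring, whereas here the added chloro group is the only difference, and the read-out cannot tell the two compounds apart. This single step says nothing about the reason for that outcome, and no further evidence bears on it.

The compounds shown leave open whether this position would stay just as undemanding with a group other than chloro, such as an amine, a methoxy group or a carboxylic acid. They also leave open how far one pair on one cell line can be generalised, as a single step within the scatter does not show that the position has no influence on growth inhibition.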